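From methoxycarbonyl to carboxy in a cytotoxicity series

The source may report more compounds than this note shows. Statements on the series, on what has been measured and on what is new or still open speak of the compounds shown alone.

Measured in a functional assay on K562 cells (Homo sapiens) for cytotoxicity, read by trypan blue exclusion, with a stated time of 96 h; on this read-out higher numbers stand for weaker inhibition and lower numbers for stronger inhibition:
- Compound 1 `COc1cc(OC)c(/C=C/S(=O)(=O)Cc2ccc(F)c(N)c2)c(OC)c1` gives 2500 nM
- Compound 2 `COc1cc(OC)c(/C=C/SCc2ccc(OC)c([N+](=O)[O-])c2)c(OC)c1` gives 5000 nM
- Compound 3 `COC(=O)C(Nc1cc(CS(=O)(=O)/C=C/c2c(OC)cc(OC)cc2OC)ccc1OC)c1ccccc1` gives 30 nM

Compound 3 has the lowest number of the three, and its distance to compound 1 and to compound 2 lies beyond the scatter of repeated measurements. Compound 1 and compound 2 lie within the scatter of each other. Compound 4 `COc1cc(OC)c(/C=C/S(=O)(=O)Cc2ccc(OC)c(NC(C(=O)O)c3ccccc3)c2)c(OC)c1` has not yet been measured. It differs from compound 3 in one place, hydrogen in place of methyl on an oxygen next to a carbonyl group in the account of the two structures. This is hydrogen in place of methyl on an oxygen next to a carbonyl group, so methoxycarbonyl becomes carboxy. Among the measured compounds shown here, no two measured compounds differ in only one place, so the data offer no direct precedent for this change. The estimate therefore starts from compound 3 at 30 nM and allows a wide margin. In this assay a moderate move toward a higher number is expected, estimated as a 3.3-fold higher number from compound 3 to compound 4 (0.52 log units; beyond the scatter) on present evidence, though a result within the scatter would not be surprising. The estimated value for compound 4 is 100 nM with an expected range of 20 nM to 600 nM once it is measured.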

Compound 4, half-maximal inhibitory concentration: 15 nM
Compound 4: middle estimate off by 6.7-fold (0.82 log units), on the high side, outside the stated range (below it).
By their numbers in this assay, from the lowest: compounds 4 and 3 (each within the scatter of the next); then compounds 1 and 2 (each within the scatter of the next).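

In this assay, among the compounds shown here, the pair gives the first direct reading of a single change in this set, a 2.0-fold lower number from compound 3 to compound 4 (0.30 log units; within the scatter), so the two compounds cannot be told apart on this read-out. Hydrogen in place of methyl on an oxygen next to a carbonyl group, which turns methoxycarbonyl into carboxy, thus leaves the number within the scatter at this position, something the earlier compounds could not show, since none of them differed from another in only one place. Nothing in the available data explains why the two compounds read alike.

What the compounds shown leave open is whether this position would read the same with other groups in place of carboxy, such as a primary amide, a hydroxymethyl group or the longer ethoxycarbonyl. The same change also rests on this one pair, so whether methoxycarbonyl and carboxy would again fall within the scatter of each other on a different core, or with another group in place of the phenyl, remains unanswered.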